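Notes on fluoro in place of methoxy

This account rests on a few compounds, and the source may have more. Where it says the series, first, only, none or still open, it means among the compounds named here.

Measured so far in a functional assay on SK-MEL-5 cells (Homo sapiens); on this read-out higher numbers stand for weaker inhibition of growth and lower numbers for stronger inhibition of growth:
- compound 1 `Cc1cnc2nc(-c3ccc(Cl)cc3)cc(O)c2c1`: 2190 nM
- compound 2 `COc1ccc(-c2cc(O)c3cc(C)cnc3n2)cc1`: 3720 nM

For the measured compounds named here, compound 2 lies within the scatter of compound 1, the only other measured compound, so no order can be read between the two. Compound 3 `Cc1cnc2nc(-c3ccc(F)cc3)cc(O)c2c1` is not yet measured. It has fluoro in place of methoxy on an aromatic carbon, para to a large group: fluoro in place of methoxy on an aromatic carbon. Going by the values given here, one measured step bears on this change, the exchange of methoxy in place of chloro on an aromatic carbon: a 1.7-fold higher number from compound 1 to compound 2 (0.23 log units; within the scatter). Among the compounds with values here, no fluoro compound has been measured, so this single small step is the only guide, and no shift beyond the scatter is expected in this assay. The expected step is a 1.4-fold lower number from compound 2 to compound 3 (0.16 log units; within the scatter). Compound 3 is estimated at 2600 nM, with an expected range of 1200 nM to 5500 nM.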

Compound 3, concentration for 50% growth inhibition: 21900 nM
Estimate against measurement, compound 3: 8.4-fold (0.93 log units) below, and the stated range ends below it.
By their numbers in this assay, from the lowest: compounds 1 and 2 (each within the scatter of the next); then compound 3.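

In this assay, the substituent para to a large group is not indifferent: methoxy and chloro could not be told apart, whereas fluoro separates from both, with the first comparison giving (a 5.9-fold higher number from compound 2 to compound 3 (0.77 log units; beyond the scatter)) and the second (a 10-fold higher number from compound 1 to compound 3 (1.00 log units; beyond the scatter)). Compound 3 therefore shows weaker inhibition of growth than either compound 1 or compound 2, and the two halogens do not behave alike at this position. Nothing available accounts for this separation.

Three compounds cannot show whether fluoro stands alone here or marks the edge of a wider trend, and bromo, trifluoromethyl, an amine or a bare hydrogen at the same carbon would test this. On these data alone, it also remains open whether the same order holds when the methyl or hydroxyl group on the shared core is replaced.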